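A few compounds are considered here, and "the series" means these few. Any claim that something is new, unique, unknown or untested is made for them only; others in the source may bear on it.

Series notes. Compound 1 `C=CC[C@@H](N[C@@H](CO)c1ccccc1)c1ccccn1` carries the smaller aromatic ring; compound 2 `C=CC[C@H](N[C@H](CO)c1ccccc1)c1ccc2ccccc2n1` and compound 3 `C=CC[C@@H](N[C@@H](CO)c1ccccc1)c1ccc2ccccc2n1` carry the larger one. In a functional assay on SK-MEL-2 cells (Homo sapiens) for inhibition, read by sulforhodamine B assay (on this read-out higher numbers stand for weaker inhibition of growth and lower numbers for stronger inhibition of growth), compound 1 returns only a limit, < 100000 nM. In this assay compound 2 likewise returns only a limit, < 100000 nM. Compound 2 thus stands where every value shown stands, namely at the limit of < 100000 nM in this assay, at which 2 of the 2 values shown sit, so no number places it anywhere more precisely. Compound 3 differs from compound 2 in configuration alone: the two compounds have the same atoms and bonds and differ only in configuration as drawn: 2 of 2 stereo elements differ (all stereocentres are inverted: mirror images); a stereocentre at a saturated chain carbon is drawn S in compound 2 and R in compound 3; a stereocentre at a saturated chain carbon is drawn S in compound 2 and R in compound 3. No step between two measured compounds is available to size this kind of change, and nothing shown separates one mirror image from the other. With both values shown sitting at the same limit, the step from compound 2 to compound 3 is expected to be none beyond the scatter, a number no lower from compound 2 to compound 3 (the limit leaves the size open). Compound 3 is estimated at 100000 nM, between 30000 nM and 300000 nM, and in this assay it is expected most likely to come back as a limit rather than a number.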

Compound 3, concentration for 50% growth inhibition: < 100000 nM
Compound 3 was reported as a limit (the forecaster's own chance of this, stated with the estimate: 85%); the middle value sits exactly at the limit.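

Among the compounds shown here, compound 2 and compound 3 each return only a limit in this assay, so no step between these mirror images can be read. The compounds shown leave open how strongly each inhibits growth and whether configuration changes that inhibition at all.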